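This account rests on a few compounds, and the source may have more. Where it says the series, first, only, none or still open, it means among the compounds named here.

Working notes on the series in a physicochemical assay for acid dissociation. Compound 1 (`CCCCS(=O)(=O)c1ccc(O)c(C(=O)Nc2ccc(C(F)(F)F)cc2)c1`) gives 6.2, compound 2 (`CCCCCCCCCCCCS(=O)(=O)c1ccc(O)c(C(=O)Nc2ccc(C(F)(F)F)cc2)c1`) gives 6.2 and compound 3 (`CCCCCCCCCCCCS(=O)(=O)c1ccc(O)c(C(=O)Nc2ccc(Br)cc2)c1`) gives 5.2. Compound 2 thus stands level with compound 1, the two together holding the highest of the three numbers, with compound 3 furthest away.

Compound 4 (`CCCCCCCCCCS(=O)(=O)c1ccc(O)c(C(=O)Nc2ccc(C(F)(F)F)cc2)c1`) is still unmeasured. Its change from compound 2 is hydrogen in place of ethyl on a saturated chain carbon, ten or more bonds along the chain from a sulfonyl sulfur.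

The closest measured change is octyl in place of hydrogen on a saturated chain carbon, four bonds along the chain from a sulfonyl sulfur, which gave no change at the digits printed from compound 1 to compound 2 (within the scatter). The other measured change, bromo in place of trifluoromethyl on an aromatic carbon, gave a number 1.00 log units lower from compound 2 to compound 3 (beyond the scatter), but compound 4 keeps the trifluoromethyl, so that size does not carry over.

The expected result in this assay is no shift beyond the scatter, in either direction, with an estimated no change at the digits printed from compound 2 to compound 4 (within the scatter). Compound 4 is expected at 6.2, within an estimated range of 5.9 to 6.5.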

Compound 4, acid dissociation constant: 6.2
For compound 4 middle estimate and measured number coincide at the digits printed; measured number inside the range.
By their numbers in this assay, from the lowest: compound 3; then compounds 1, 2 and 4 (each within the scatter of the next).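

In this assay, the change at this far end of the chain gives no change at the digits printed from compound 2 to compound 4 (within the scatter), so hydrogen in place of ethyl leaves the read-out level. Among the compounds shown here, with the trifluoromethyl kept, the longer chain step gives no change at the digits printed from compound 1 to compound 4 (within the scatter), which adds a third chain to the single chain step seen earlier, and all three read alike. Nothing measured here accounts for this result.

Still open, from the compounds shown here alone, is whether an amine or a carboxylic acid at the far end of the chain would also leave the number level. Also open is whether the chain steps read the same with bromo in place of trifluoromethyl, as the one bromo compound shown carries the chain of compound 2.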